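A few compounds are considered here, and "the series" means these few. Any claim that something is new, unique, unknown or untested is made for them only; others in the source may bear on it.

Of the compounds shown here, three with the same core have been measured in a functional assay on K562 cells (Homo sapiens) for cytotoxicity, read by MTT assay, with a stated time of 72 h; a higher number here means a weaker inhibitor, a lower number a stronger inhibitor. Compound 1 `[O-][n+]1nc(NCOC2CCCCC2)[n+]([O-])c2ccccc21` gives 10800 nM in this assay, compound 2 `CCOCNc1n[n+]([O-])c2ccccc2[n+]1[O-]` gives 15400 nM, and compound 3 `CCCOCNc1n[n+]([O-])c2ccccc2[n+]1[O-]` gives 17600 nM. Compound 3 carries the highest of the three numbers, but the steps to it, a 1.6-fold higher number from compound 1 to compound 3 (0.21 log units; within the scatter) and a 1.1-fold higher number from compound 2 to compound 3 (0.06 log units; within the scatter), both fall within the scatter of the measurement, so the three compounds cannot be told apart on these numbers.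

Compound 4 `CCCCOCNc1n[n+]([O-])c2ccccc2[n+]1[O-]` is the next member of the chain series. Set against compound 3, the change is methyl in place of hydrogen on a saturated chain carbon, three bonds along the chain from an oxygen on a saturated carbon. The step that bears most directly on it is the one in which the chain grew by the same unit one bond closer to the oxygen, a 1.1-fold higher number from compound 2 to compound 3 (0.06 log units; within the scatter), which stayed within the scatter. The replacement of the cyclohexyl by the shorter chains, a 1.4-fold higher number from compound 1 to compound 2 (0.15 log units; within the scatter) and a 1.6-fold higher number from compound 1 to compound 3 (0.21 log units; within the scatter), also stayed within the scatter. Among the compounds with values here, nothing among the measured compounds therefore points to a step beyond the scatter, in either direction, for compound 4 in this assay.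

Compound 4 is accordingly expected to give about 19000 nM in this assay, with a range from 9000 nM to 40000 nM. The step that this estimate implies, a 1.1-fold higher number from compound 3 to compound 4 (0.03 log units; within the scatter), is expected to stay within the scatter.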

Compound 4, half-maximal inhibitory concentration: 17600 nM
Estimate against measurement, compound 4: 1.1-fold (0.03 log units) above; measured number inside the range.
By their numbers in this assay, from the lowest: compounds 1, 2, 3 and 4 (each within the scatter of the next).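

Growing the chain from propyl to butyl, with the new methyl three bonds along the chain from an oxygen on a saturated carbon, gives no change at the digits printed from compound 3 to compound 4 (within the scatter) in this assay, so a second chain extension, one bond further out than the last, also stays within the scatter. The larger change in the chain gives a 1.1-fold higher number from compound 2 to compound 4 (0.06 log units; within the scatter), and even this wider change in chain length cannot be told apart from no change, while butyl in place of cyclohexyl gives a 1.6-fold higher number from compound 1 to compound 4 (0.21 log units; within the scatter), so the ring and the butyl chain cannot be told apart either. No supporting measurement is available to account for this lack of separation.

On these data alone, all four compounds carry only saturated carbon groups on that oxygen, so it remains open whether a much longer chain such as octyl, or a phenyl ring, would take the number beyond the scatter. As far as these compounds go, it is equally open whether an amine or a carboxylic acid at the end of the chain would leave the number where it stands.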